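The compounds below may be only part of what the source reports. "The series", "measured", "known", "first", "only" and "open" are said of these compounds alone.

Series notes. Compound 1 `C[C@@]12CCCC[C@H]1CC=C(O)C2=O` is tested in an ADME assay on MCF-10A cells (Homo sapiens) for antiproliferative activity, read by sulforhodamine B assay, with a stated time of 48 h; a higher number here means a weaker inhibitor, a lower number a stronger inhibitor. In this assay compound 1 returns only a limit, > 2000000 nM. Compound 2 `C[C@H]1N=C2C[C@H]3C[C@H](C3(C)C)[C@@]2(C)OC1=O` likewise gives a limit in this assay, > 1800000 nM. Compound 3 `CC(C)(C)OC(=O)NCCC[C@@H]1N=C2C[C@@H]3C[C@@H](C3(C)C)[C@]2(C)OC1=O` also reaches only a limit in this assay, > 1200000 nM. Compound 2 thus stands at a limit, as do the other two values shown; none is a number, so no ordering among compounds 1, 2 and 3 can be read. Compound 4 `CC1(C)[C@H]2CC3=N[C@H](CCC(=O)O)C(=O)O[C@]3(C)[C@@H]1C2` is not yet measured in this assay. It differs from compound 2 in one place: carboxymethyl in place of hydrogen on a saturated chain carbon bound to a saturated ring carbon. Among the measured compounds shown here, no step between measured compounds is available, and no step beyond the scatter is expected. Compound 4 is expected to give 1800000 nM, within 900000 nM to 3600000 nM, most probably again only as a limit. The step from compound 2 to compound 4 is estimated at a number no higher from compound 2 to compound 4 (the limit leaves the size open).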

Compound 4, half-maximal inhibitory concentration: > 1200000 nM
Compound 4 was reported as a limit; the forecaster's own chance of this, stated with the estimate: 85%; the middle value lies beyond the limit too.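

Among the compounds shown here, compound 2 and compound 4 both return only limits in this assay, so no step between them can be read. The compounds shown leave open whether carboxymethyl in place of hydrogen changes the value in this assay at all.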